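Swapping the alkyne for phenyl, then adding a chloro

The compounds below may be only part of what the source reports. "The series", "measured", "known", "first", "only" and "open" are said of these compounds alone.

Of the compounds shown here, three sharing one core have been measured. Compound 1 `CCCCC#Cc1cc([C@@H]2O[C@H](CO)[C@@H](O)[C@H]2O)n2ncnc(N)c12` gives 200 nM in a functional assay on Z-138 cells (Homo sapiens) for antiproliferative activity, with a stated time of 72 h; a higher number here means a weaker inhibitor, a lower number a stronger inhibitor. Compound 2 `Nc1ncnn2c([C@@H]3O[C@H](CO)[C@@H](O)[C@H]3O)cc(C#CC3CC3)c12` gives 20 nM, a step of a 10-fold lower number from compound 1 to compound 2 (1.00 log units; beyond the scatter). Compound 3 `Nc1ncnn2c([C@@H]3O[C@H](CO)[C@@H](O)[C@H]3O)cc(-c3ccccc3)c12` reaches only the limit of this assay, > 100000 nM. That limit, (the limit of > 100000 nM in this assay, at which 1 of the 3 values shown sits), is where compound 3 stands, after steps of an at least 500-fold higher number from compound 1 to compound 3 (2.69 log units; beyond the scatter) and an at least 5000-fold higher number from compound 2 to compound 3 (3.69 log units; beyond the scatter). Compound 4 `Nc1ncnn2c([C@@H]3O[C@H](CO)[C@@H](O)[C@H]3O)cc(-c3ccc(Cl)cc3)c12` differs from compound 3 by chloro in place of hydrogen on an aromatic carbon. Going by the values given here, no measured step touches a change of this kind, and from a limit no step can be read. Compound 4 is therefore expected near 100000 nM, between 20000 nM and 300000 nM. The expected step of a number no higher from compound 3 to compound 4 (the limit leaves the size open) is thus none beyond the scatter.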

Compound 4, half-maximal inhibitory concentration: 40200 nM
Compound 4: middle estimate off by 2.5-fold (0.40 log units), on the high side; the measured number falls inside the stated range.
By their numbers in this assay, from the lowest: compound 2; then compound 1; then compound 4. At a limit, above all of these: compound 3.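

Compound 3 stands at a limit, not at a number: the limit of > 100000 nM in this assay, at which 1 of the 4 values shown sits. Going from phenyl to 4-chlorophenyl still gives a real number, with an at least 2.4-fold lower number from compound 3 to compound 4 (0.39 log units; beyond the scatter), so a single chlorine on this aromatic group can shift activity. The aromatic group nevertheless remains far behind both alkynes, with a 2000-fold higher number from compound 2 to compound 4 (3.30 log units; beyond the scatter) and a 200-fold higher number from compound 1 to compound 4 (2.30 log units; beyond the scatter). Open, from the compounds shown here alone, is whether another group in place of chloro, such as methoxy, an amine or a carboxylic acid, would move the number further, or whether it could approach the alkynes.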